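Methoxy for chloro on the aryl of compound 3

A few compounds are considered here, and "the series" means these few. Any claim that something is new, unique, unknown or untested is made for them only; others in the source may bear on it.

The measured compounds:
compound 1, `Cc1nn(C)c(Oc2ccc(Cl)cc2)c1/C=N\OCc1c(Cl)c(-c2ccc(F)cc2)nn1C`, 6030 nM
compound 2, `Cc1ccc(Oc2c(/C=N\OCc3c(Cl)c(-c4ccc(F)cc4)nn3C)c(C)nn2C)cc1`, 2910 nM
compound 3, `Cc1nn(C)c(Oc2ccc(Cl)cc2)c1/C=N\OCc1c(Cl)c(-c2ccc(Cl)cc2)nn1C`, 4670 nM

In a functional assay on HCT-116 cells (Homo sapiens) for antiproliferative activity, read by MTT assay, with a stated time of 72 h (on this read-out higher numbers stand for weaker inhibition and lower numbers for stronger inhibition), compound 3 gives 4670 nM, the second highest of the three numbers; its nearest neighbour is compound 1 with 6030 nM, within the scatter, and its furthest is compound 2 with 2910 nM, also within the scatter.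

The step to compound 4, `COc1ccc(Oc2c(/C=N\OCc3c(Cl)c(-c4ccc(Cl)cc4)nn3C)c(C)nn2C)cc1`, is methoxy in place of chloro on an aromatic carbon, read one bond further out as 4-chlorophenyl to 4-methoxyphenyl.

Among the compounds with values here, two measured steps bear on it. The exchange at the same ring, chloro in place of fluoro, gave a 1.3-fold lower number from compound 1 to compound 3 (0.11 log units; within the scatter). The exchange at the other ring, methyl in place of chloro, gave a 2.1-fold lower number from compound 1 to compound 2 (0.32 log units; beyond the scatter). Within the data shown here, neither step puts a methoxy at this ring, so the data say nothing directly about a methoxy there; the one change already made at this ring stayed within the scatter.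

Compound 4 is therefore expected to sit close to compound 3, with a step of a 1.2-fold lower number from compound 3 to compound 4 (0.07 log units; within the scatter) that is not expected to reach beyond the scatter. The estimate for compound 4 in this assay is 4000 nM, with a range from 1800 nM to 9000 nM.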

Compound 4, half-maximal inhibitory concentration: 1260 nM
Beside the measured number, compound 4's estimate is 3.2-fold (0.50 log units) above it; measured number outside the range, below it.
By their numbers in this assay, from the lowest: compound 4; then compounds 2, 3 and 1 (each within the scatter of the next, the first and the last beyond it).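

The exchange lies on the phenoxy ring, as 4-chlorophenoxy to 4-methoxyphenoxy, while the 4-chlorophenyl ring stays the same in compound 3 and compound 4. In this assay methoxy in place of chloro gives a 3.7-fold lower number from compound 3 to compound 4 (0.57 log units; beyond the scatter) and methyl in place of chloro at this same place gave a 2.1-fold lower number from compound 1 to compound 2 (0.32 log units; beyond the scatter) in the series with the fluoro group, so both replacements of this chloro lower the number, whereas the exchange on the other ring, a 1.3-fold lower number from compound 1 to compound 3 (0.11 log units; within the scatter), did not go beyond the scatter. Nothing measured here accounts for the effect of the methoxy at this position.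

The compounds shown leave open whether methoxy at this place gives a similar step when the other ring carries fluoro instead of chloro, and whether the lower number depends on the second change at all. They also leave open how an ethoxy group, an amine or a carboxylic acid at this place, para to a large group, would compare with methoxy and methyl.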